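Replacing one group on compound 3

This account rests on a few compounds, and the source may have more. Where it says the series, first, only, none or still open, it means among the compounds named here.

Measured in a functional assay on RS4-11 cells (Homo sapiens) for inhibition, read by CCK-8 assay, with a stated time of 48 h; on this read-out lower numbers stand for stronger inhibition and higher numbers for weaker inhibition:
- compound 1 `O=S(=O)(NCCNC(=S)Nc1cccc(Cl)c1)c1ccc(-c2ccccc2OCc2cccc(O)c2)s1`: 5800 nM
- compound 2 `COc1ccc(NC(=O)NCCNS(=O)(=O)c2ccc(-c3ccccc3OCc3ccccc3)s2)cc1`: > 20000 nM (a limit)
- compound 3 `O=S(=O)(NCCNC(=S)Nc1cccc(Cl)c1)c1ccc(-c2ccccc2OCc2ccccc2)s1`: > 50000 nM (a limit)

Compound 3 has no exact number, only the limit > 50000 nM. Compound 4 `COc1cccc(NC(=O)NCCNS(=O)(=O)c2ccc(-c3ccccc3OCc3ccccc3)s2)c1` has not yet been measured. It keeps the core of compound 3 but exchanges one group on an amine nitrogen: a group of 11 heavy atoms (8 carbon, 1 nitrogen, 2 oxygen; one six-membered aromatic ring of carbon only) in place of a group of 10 heavy atoms (7 carbon, 1 nitrogen, 1 sulfur, 1 chlorine; one six-membered aromatic ring of carbon only), on an amine nitrogen.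

Among the measured compounds shown here, two measured steps bear on this change. The closer one is a step that the two limits leave unreadable from compound 2 to compound 3, which involves a group of the same size and makeup as the incoming one, but it gives no usable size. The other is an at least 8.6-fold higher number from compound 1 to compound 3 (0.93 log units; beyond the scatter), which involves a hydroxy group. Compound 4 lacks that hydroxy group, as compound 3 does. Compound 1 carries it and gives 5800 nM. The nearest comparison for compound 4 is compound 2, which gives only a limit, > 20000 nM.

For the measured compounds named here, no measured step fixes the size of this exchange, so any expected shift is very uncertain, and a reported limit is the likeliest result. The expected change is an at least 1.6-fold lower number from compound 3 to compound 4 (0.22 log units; that floor lies within the scatter). The estimated value for compound 4 is 30000 nM, with an expected range from 12000 nM to 60000 nM.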

Compound 4, half-maximal inhibitory concentration: > 20000 nM
Compound 4 gave a limit, no number; the forecaster's own chance of this, stated with the estimate: 75%; the middle value is on the limit's open side.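

Compound 2, compound 3 and compound 4 each give only a limit, not a number, so the steps linking compound 4 to compound 3 and to compound 2 cannot be read. The compounds shown leave open whether 3-methoxyphenyl and 4-methoxyphenyl differ in this assay, and how far the group exchanged on compound 3 shifts the result.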